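Working notes: 2-hydroxyethoxy in place of phenyl

This account rests on a few compounds, and the source may have more. Where it says the series, first, only, none or still open, it means among the compounds named here.

Measured so far:
- compound 1 `NC(=O)c1cn(Cc2ccccc2)c2ncnc(N)c12`: in a functional assay on KB cells (Homo sapiens) for cytotoxicity (on this read-out higher numbers stand for weaker inhibition and lower numbers for stronger inhibition), compound 1 gives 75000 nM
- compound 2 `NC(=S)c1cn(Cc2ccccc2)c2ncnc(N)c12`: in this assay compound 2 gives 32000 nM
- compound 3 `N#Cc1cn(Cc2ccccc2)c2ncnc(N)c12`: in this assay compound 3 reaches only a limit, > 100000 nM

Compound 2 holds the lowest of the two numbers available, with a 2.3-fold lower number from compound 1 to compound 2 (0.37 log units; beyond the scatter) lying beyond the scatter. Compound 3 sits at the limit of > 100000 nM in this assay, at which 1 of the 3 values shown sits.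

Compound 4 `NC(=S)c1cn(COCCO)c2ncnc(N)c12` differs from compound 2 by 2-hydroxyethoxy in place of phenyl on a saturated chain carbon bound to an aromatic nitrogen. Every measured step here concerns the group on the aromatic carbon: a 2.3-fold lower number from compound 1 to compound 2 (0.37 log units; beyond the scatter), an at least 3.1-fold higher number from compound 2 to compound 3 (0.49 log units; beyond the scatter) and an at least 1.3-fold higher number from compound 1 to compound 3 (0.12 log units; that floor lies within the scatter). Among the compounds with values here, none touches the group on the saturated chain carbon bound to an aromatic nitrogen, so no measured step bears directly on this change. With no guide, only a small shift toward a higher number is expected, a 1.6-fold higher number from compound 2 to compound 4 (0.19 log units; within the scatter). Compound 4 is therefore estimated at 50000 nM in this assay, within 15000 nM to 200000 nM.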

Compound 4, half-maximal inhibitory concentration: 115000 nM
Compound 4: the middle estimate sits 2.3-fold (0.36 log units) below what was measured, and the stated range covers the measured number.
By their numbers in this assay, from the lowest: compound 2; then compounds 1 and 4 (each within the scatter of the next).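

The group on the saturated chain carbon bound to an aromatic nitrogen also moves the read-out, not only the group on the aromatic carbon: with the thioamide held constant, 2-hydroxyethoxy in place of phenyl gives a 3.6-fold higher number from compound 2 to compound 4 (0.56 log units; beyond the scatter). This step shows that the phenyl ring cannot be exchanged here for this open chain without a change beyond the scatter. Nothing shown bears on the reason for this step.

Going by these compounds, whether a methoxyethyl chain, a longer alkyl chain or a substituted benzyl group would behave like phenyl or like 2-hydroxyethoxy remains open. So does whether this step carries over to the carbamoyl or cyano compounds.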